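From Ethyl to Ethoxy on the Side Chain

This account rests on a few compounds, and the source may have more. Where it says the series, first, only, none or still open, it means among the compounds named here.

In a functional assay on a cell-free system (plasma, Homo sapiens) for inhibition, with Plasma (Rattus norvegicus) as the target (on this read-out lower numbers stand for stronger inhibition and higher numbers for weaker inhibition), compound 1 `O=c1cc(N2CCNCC2)c2c(OCc3ccccc3)cccc2o1` gives 187000 nM, while compound 2 `CCCOc1ccc2c(N3CCNCC3)cc(=O)oc2c1C` gives 2950 nM, the lower of the two numbers and so the stronger inhibition. Compound 3 `CCOCOc1ccc2c(N3CCNCC3)cc(=O)oc2c1C` differs from compound 2 in one place: ethoxy in place of ethyl on a saturated chain carbon bound to an oxygen on an aromatic ring. This puts ethoxy in place of ethyl on a saturated chain carbon bound to an oxygen on an aromatic ring. For the measured compounds named here, no measured pair shows this kind of change, so only a modest weakening is expected, an estimated 1.4-fold higher number from compound 2 to compound 3 (0.13 log units; within the scatter). Compound 3 is expected to give about 4000 nM, within a range of 1300 nM to 12000 nM.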

Compound 3, half-maximal inhibitory concentration: 1800 nM
Beside the measured number, compound 3's estimate is 2.2-fold (0.35 log units) above it; measured number inside the range.
By their numbers in this assay, from the lowest: compounds 3 and 2 (each within the scatter of the next); then compound 1.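

In this assay the swap of ethyl for ethoxy on a saturated chain carbon bound to an oxygen on an aromatic ring gives a 1.6-fold lower number from compound 2 to compound 3 (0.21 log units; within the scatter) so compound 2 and compound 3 cannot be told apart. This position therefore tolerates the extra oxygen and its added hydrogen-bond acceptor, with no loss of inhibition beyond the scatter. Nothing available accounts for this result. From the compounds shown here alone, what an amine, a carboxylic acid or a longer chain would do in place of ethoxy at this position stays open.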